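The source may report more compounds than this note shows. Statements on the series, on what has been measured and on what is new or still open speak of the compounds shown alone.

Compound 1 `N#Cc1c(O)nc(SCc2nc3ccccc3[nH]2)nc1-c1ccccc1` was tested in a functional assay on U-937 cells (Homo sapiens) for cytotoxicity, read by MTT assay, with a stated time of 3 days (on this read-out higher numbers stand for weaker inhibition and lower numbers for stronger inhibition), and gives 3.28 nM. Its one measured neighbour, compound 2 `N#Cc1c(Nc2ccccc2)nc(SCc2nc3ccccc3[nH]2)nc1-c1ccccc1`, gives 3.28 nM in this assay, so compound 1 stands level with compound 2 at the digits shown. The step from compound 1 to compound 2 was no change at the digits printed from compound 1 to compound 2 (within the scatter), and the change there was anilino in place of hydroxy on an aromatic carbon. Compound 3 `CNc1nc(SCc2nc3ccccc3[nH]2)nc(-c2ccccc2)c1C#N` is not yet measured; it differs from compound 1 by methylamino in place of hydroxy on an aromatic carbon, at the same place where compound 2 carries its anilino group. For the measured compounds named here, the only step that bears on this change, from compound 1 to compound 2, stayed within the scatter, so no step beyond the scatter is expected in this assay. Compound 3 is therefore estimated at 3.5 nM, with a range from 1.2 nM to 10 nM; this expectation means a step of a 1.1-fold higher number from compound 1 to compound 3 (0.03 log units; within the scatter).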

Compound 3, half-maximal inhibitory concentration: 19.2 nM
Beside the measured number, compound 3's estimate is 5.5-fold (0.74 log units) below it, outside the stated range (above it).
By their numbers in this assay, from the lowest: compounds 1 and 2 (each within the scatter of the next); then compound 3.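

In this assay, methylamino in place of hydroxy on this aromatic carbon gives a 5.9-fold higher number from compound 1 to compound 3 (0.77 log units; beyond the scatter) and so shows that the number does respond to the group placed here, which the earlier pair could not show. Measured against the anilino compound, methyl in place of phenyl on the same nitrogen gives a 5.9-fold higher number from compound 2 to compound 3 (0.77 log units; beyond the scatter) and so shows that what is attached to this nitrogen matters, with the phenyl compound sitting level with the hydroxy compound and the methyl compound apart from both. Nothing measured here explains why the number rises.

The compounds shown leave open where a longer chain on the nitrogen, such as ethylamino or benzylamino, would fall between these values. They also leave open how a plain amino group or a methoxy group would behave at this carbon.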